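Series notes: the other enantiomer of compound 3

The source may report more compounds than this note shows. Statements on the series, on what has been measured and on what is new or still open speak of the compounds shown alone.

Measured so far:
Compound 1 `CCCC(/N=C(\S)NCc1ccc(C(C)(C)C)cc1)c1ccc(NS(C)(=O)=O)cc1`: 1490 nM
Compound 2 `C[C@@H](/N=C(\S)NCc1ccc(C(C)(C)C)cc1)c1ccc(C(C)(C)C)cc1`: 3490 nM
Compound 3 `C[C@@H](/N=C(\S)NCc1ccc(C(C)(C)C)cc1)c1ccc([N+](=O)[O-])cc1`: 580 nM

All three were run in a functional assay for inhibition, with Rattus norvegicus as the target; on this read-out higher numbers stand for weaker inhibition and lower numbers for stronger inhibition. Compound 3 holds the lowest number of the three, the value of compound 1 lying closer to it than that of compound 2. Going by the values given here, the one single-point step on record is a 6.0-fold lower number from compound 2 to compound 3 (0.78 log units; beyond the scatter).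

Compound 4 `C[C@H](/N=C(\S)NCc1ccc(C(C)(C)C)cc1)c1ccc([N+](=O)[O-])cc1` is not yet measured. It differs from compound 3 only in configuration: the two compounds have the same atoms and bonds and differ only in configuration as drawn: 1 of 2 stereo elements differ; a stereocentre at a saturated chain carbon is drawn R in compound 3 and S in compound 4. Among the compounds with values here, no measured step concerns a change in configuration; the step of a 6.0-fold lower number from compound 2 to compound 3 (0.78 log units; beyond the scatter) is a change of substituent and gives no guidance here. Without any such step, a somewhat weaker number is expected for compound 4, a 2.6-fold higher number from compound 3 to compound 4 (0.41 log units; beyond the scatter), with a wide range around it. Compound 4 is estimated at 1500 nM, between 350 nM and 6500 nM.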

Compound 4, half-maximal inhibitory concentration: 14700 nM
The estimate for compound 4 lay 9.8-fold (0.99 log units) below the measured number; the whole stated range lies below it.
By their numbers in this assay, from the lowest: compound 3; then compound 1; then compound 2; then compound 4.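

In this assay the configuration at the saturated chain carbon proves decisive, with a 25-fold higher number from compound 3 to compound 4 (1.40 log units; beyond the scatter) on going from R to S at this one stereocentre. Going by these compounds alone, the only earlier step changed an aromatic substituent, so it gave no reading of this position. The shift can be assigned to configuration alone because nothing else separates the pair: the fact that compounds 3 and 4 differ only in the configuration as drawn

Still open, from the compounds shown here alone, is whether R stays favoured with the tert-butyl group of compound 2 on the aromatic ring. Also open, going by these compounds, is how an amine or a carboxylic acid in place of the nitro group of compound 3 would read out.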